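Inverting one chain stereocentre of compound 1

A few compounds are considered here, and "the series" means these few. Any claim that something is new, unique, unknown or untested is made for them only; others in the source may bear on it.

In a functional assay on the whole organism (strain Hartley) for inhibition, with Cavia porcellus as the target, with stated times of 15 min and 2 min (on this read-out lower numbers stand for an effect already at smaller amounts and higher numbers for an effect only at larger amounts of compound), compound 1 `CCCCC1([C@H](O)/C=C/C2[C@H](O)CC(=O)[C@@H]2C/C=C\CCCC(=O)O)CCC1` gives 0.00154 mg/kg and compound 2 `CCCCC1([C@H](O)/C=C/C2CCC(=O)[C@@H]2C/C=C\CCCC(=O)O)CCC1` gives 0.0022 mg/kg. The two sit level within the scatter, at the low end of the numbers available. Compound 3 `CCCCC1([C@@H](O)/C=C/C2CCC(=O)[C@@H]2CCCCSCC(=O)OCC)CCC1` reports only a limit, > 0.672 mg/kg.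

Compound 4 `CCCCC1([C@@H](O)/C=C/C2[C@H](O)CC(=O)[C@@H]2C/C=C\CCCC(=O)O)CCC1` is the next compound to consider, and its relation to compound 1 is simple: the two compounds have the same atoms and bonds; at least one stereo element is drawn with a configuration in one of them and without one in the other: 1 of 6 stereo elements differ; a stereocentre at a saturated chain carbon is drawn R in compound 1 and S in compound 4. Among the compounds with values here, the only measured step, a 1.4-fold higher number from compound 1 to compound 2 (0.15 log units; within the scatter), lies within the scatter. It concerns a different place in the structure and does not test the configuration of this stereocentre. Within the data shown here, no measured pair isolates an inversion, so the size of the change remains a judgement.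

Much higher numbers are possible in this series, as compound 3 shows with the limit of > 0.672 mg/kg in this assay, at which 1 of the 3 values shown sits. That compound is only a loose guide, since it is not a direct stereochemical comparison. A large shift beyond the scatter is nevertheless expected for a change in stereochemistry on the chain. The estimated change is a 65-fold higher number from compound 1 to compound 4 (1.81 log units; beyond the scatter), expected towards a higher number in this assay. Compound 4 is expected at 0.1 mg/kg, with an estimated range of 0.015 mg/kg to 0.7 mg/kg.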

Compound 4, dose for half-maximal effect: 0.0484 mg/kg
Compound 4: the middle estimate sits 2.1-fold (0.32 log units) above what was measured; the range from low to high includes it.
By their numbers in this assay, from the lowest: compounds 1 and 2 (each within the scatter of the next); then compound 4. At a limit, above all of these: compound 3.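

Inverting the stereocentre at a saturated chain carbon, with atoms and bonds unchanged, gives the first measured stereochemical step in the series: in this assay the change is a 31-fold higher number from compound 1 to compound 4 (1.50 log units; beyond the scatter). Within the data shown here, of the two single-place changes now available, only this one moves the number beyond the scatter, whereas hydrogen in place of hydroxy on a saturated ring carbon gives a 1.4-fold higher number from compound 1 to compound 2 (0.15 log units; within the scatter), which stays within it. The configuration at this chain carbon therefore counts for far more in this assay than the ring hydroxy does, yet compound 4 still gives a measured number, 0.0484 mg/kg, rather than a limit.

Going by these compounds, whether the inversion carries the same size of step without the ring hydroxy stays open, since compound 2 has no partner inverted at the chain carbon. Also open is whether the configuration alone sets the step or a methoxy group in place of the hydroxy at this saturated chain carbon would give a similar shift, as the shown compounds keep the hydroxy there wherever the comparison can be read.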